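The source may hold more compounds than are shown below. What is called first, only, known or untested is meant among the compounds shown, and "the series" means these compounds.

Within the data shown here, compound 1 `CCOc1cc(NC(=O)CCCCC(=O)Nc2cc(-c3ccc(C)s3)ccc2N)cc2c1OCC([N+](=O)[O-])=C2` in a functional assay on MCF7 cells (Homo sapiens) for antiproliferative activity, read by MTT assay, with a stated time of 48 h (a lower number here means a stronger inhibitor of growth, a higher number a weaker inhibitor of growth), gives 7910 nM and holds the only number in the set. Compound 2 `CCOc1cc(NC(=O)CCCCCC(=O)Nc2cc(-c3ccc(C)s3)ccc2N)cc2c1OCC([N+](=O)[O-])=C2` in this assay returns only a limit, > 20000 nM. That limit of > 20000 nM in this assay, at which 1 of the 2 values shown sits, leaves the step from compound 1 to compound 2 without a size. Compound 3 `CCOc1cc(NC(=O)CCCCC(=O)Nc2cc(-c3ccccc3)ccc2N)cc2c1OCC([N+](=O)[O-])=C2` differs from compound 1 by phenyl in place of 5-methylthiophen-2-yl on an aromatic carbon. Among the measured compounds shown here, no measured pair covers this aryl exchange, so its size cannot be read from the data; the move is expected to stay within the scatter or weaken growth inhibition slightly. For compound 3 the expected step is a 1.3-fold higher number from compound 1 to compound 3 (0.10 log units; within the scatter). Compound 3 is estimated at 10000 nM, between 4000 nM and 25000 nM.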

Compound 3, concentration for 50% growth inhibition: 19900 nM
For compound 3 the middle estimate is 2.0-fold (0.30 log units) below the measured one, within the range that was stated.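

On an aromatic carbon para to an amino group, the aryl group matters in this assay: a 2.5-fold higher number from compound 1 to compound 3 (0.40 log units; beyond the scatter) follows when phenyl replaces 5-methylthiophen-2-yl. Among these compounds, this is the first step with a size, and it is modest, so this position tolerates the exchange while still favouring compound 1 over compound 3. No measurement shown gives a cause for this step.

The exchange changes the ring and removes the methyl at once, so the share of each stays unresolved. Going by these compounds, an unsubstituted thiophen-2-yl or a pyridine ring here, and a shorter chain in the diamide linker, remain open.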